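Cyclic Amine Replacing the Benzyl(methyl)amino Chain End

The compounds below may be only part of what the source reports. "The series", "measured", "known", "first", "only" and "open" are said of these compounds alone.

Compound 1 `COc1cc2c(Nc3ccc(C#N)cc3)ncnc2cc1OCCCN(C)C`: > 100000 nM
Compound 2 `COc1cc2c(Nc3ccc(C#N)cc3)ncnc2cc1OCCCN(C)Cc1ccccc1`: > 100000 nM
Compound 3 `COc1cc2c(Nc3ccc(C#N)cc3)ncnc2cc1OCCCN1CCCC1`: 20900 nM
Compound 4 `COc1cc2c(Nc3ccc(C#N)cc3)ncnc2cc1OCCCN1CCc2ccccc2C1`: not yet measured

In a functional assay on HepG2 cells (Homo sapiens) for antiproliferative activity, read by MTT assay, with a stated time of 72 h (on this read-out lower numbers stand for stronger inhibition and higher numbers for weaker inhibition), compound 2 gives only a limit, > 100000 nM. Compound 1 likewise sits at a limit, > 100000 nM. For the measured compounds named here, compound 3 is the sole compound with a number, 20900 nM. Compound 4 differs from compound 2 by 1,2,3,4-tetrahydroisoquinolin-2-yl in place of benzyl(methyl)amino on a saturated chain carbon, three bonds along the chain from an oxygen on an aromatic ring. The closest guide is the step of an at least 4.7-fold lower number from compound 2 to compound 3 (0.67 log units; beyond the scatter), and an at least 4.7-fold lower number from compound 1 to compound 3 (0.67 log units; beyond the scatter) points the same way; the limit of > 100000 nM in this assay, at which 2 of the 3 values shown sit, means both steps are known only as lower bounds. For compound 4 a comparable fall is therefore expected, an at least 3.3-fold lower number from compound 2 to compound 4 (0.52 log units; beyond the scatter). The estimate for compound 4 is 30000 nM, with a range from 8000 nM to 150000 nM.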

Compound 4, half-maximal inhibitory concentration: > 100000 nM
Compound 4: no number, only a limit (the forecaster's own chance of this, stated with the estimate: 35%); at least 3.3-fold (0.52 log units) between middle value and limit.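

In this assay, a cyclic amine at the chain end is not enough on its own: 1,2,3,4-tetrahydroisoquinolin-2-yl does not keep the gain seen with pyrrolidin-1-yl, with an at least 4.7-fold higher number from compound 3 to compound 4 (0.67 log units; beyond the scatter). Among the four amines shown, only pyrrolidin-1-yl gives a value that is not a limit. The steps to compound 4 from compound 1 and compound 2 cannot be read: the limit of > 100000 nM in this assay, at which 3 of the 4 values shown sit.

Going by these compounds, it remains open how piperidin-1-yl or morpholin-4-yl would fare at this chain end. Also open, on these data alone, is whether pyrrolidin-1-yl would keep its value on a longer chain.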